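A few compounds are considered here, and "the series" means these few. Any claim that something is new, unique, unknown or untested is made for them only; others in the source may bear on it.

Of the compounds shown here, three from this series have been measured. Compound 1 `Clc1ccc(-c2cc(-c3ccsc3)nc(-c3ccccc3Cl)c2)o1` gives 0% in an assay on isolated protein for inhibition of DNA topoisomerase 1 (Homo sapiens), tested at 100 uM; on this read-out lower numbers stand for a weaker effect and higher numbers for a stronger effect at the one concentration tested. Compound 2 `Cc1cccc(-c2cc(-c3ccc(Cl)o3)cc(-c3ccsc3)n2)c1` gives 7.5% in this assay, and the step of a number 7.5 percentage points higher from compound 1 to compound 2 (within the scatter) therefore carries no weight. Compound 3 `Clc1ccc(-c2cc(-c3ccc(Cl)o3)cc(-c3ccsc3)n2)cc1` gives 29.8% in this assay, the highest of the three numbers: its nearest neighbour is compound 2, separated by a number 22.3 percentage points higher from compound 2 to compound 3 (beyond the scatter), and the furthest is compound 1, separated by a number 29.8 percentage points higher from compound 1 to compound 3 (beyond the scatter).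

Compound 4 `Clc1cccc(-c2cc(-c3ccc(Cl)o3)cc(-c3ccsc3)n2)c1` has not yet been measured. It differs from compound 3 in one place: 3-chlorophenyl in place of 4-chlorophenyl on an aromatic carbon. Both measured steps that end at compound 3 bear on this change, since each of them also swaps the aromatic group at the same place. The step of a number 29.8 percentage points higher from compound 1 to compound 3 (beyond the scatter) and the step of a number 22.3 percentage points higher from compound 2 to compound 3 (beyond the scatter) both show the 4-chlorophenyl giving the highest reading, while a 2-chlorophenyl and a 3-methylphenyl sit low. Moving away from the 4-chlorophenyl is therefore expected to lower the number, and the step of a number 17.8 percentage points lower from compound 3 to compound 4 (beyond the scatter) is the expected size of that drop, a modest one. For compound 4 the expected value in this assay is 12%, with a range from 0% to 30%.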

Compound 4, a percentage reported as inhibition, at one concentration (the size of the read-out at that concentration, not a potency): 0%
Beside the measured number, compound 4's estimate is 12 percentage points above it, within the range that was stated.
By their numbers in this assay, from the lowest: compounds 1, 4 and 2 (each within the scatter of the next); then compound 3.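

In this assay, the 3-chlorophenyl and 4-chlorophenyl groups have the same atoms, yet a number 29.8 percentage points lower from compound 3 to compound 4 (beyond the scatter) is as large as the widest step seen so far, so the reading at this place depends on where the chlorine sits on the phenyl group and not merely on its presence. Among these compounds, the 3-chlorophenyl group also falls in with the two low compounds, with no change at the digits printed from compound 1 to compound 4 (within the scatter) and a number 7.5 percentage points lower from compound 2 to compound 4 (within the scatter), which leaves the 4-chlorophenyl of compound 3 as the only group here that stands clear of the others, and shows that chloro in place of methyl makes no readable difference on this phenyl group. Nothing available gives a reason for this sharp dependence on the chlorine's location.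

As far as these compounds go, what stays open is whether the chlorine itself matters in compound 3 or whether another group in its place, such as fluoro, methyl, methoxy, an amine or a carboxylic acid on the same phenyl carbon, would give a similar reading. From the compounds shown here alone, it is equally open how much the 5-chlorofuran-2-yl and thiophen-3-yl groups contribute to the reading of compound 3.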